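The source may report more compounds than this note shows. Statements on the series, on what has been measured and on what is new or still open speak of the compounds shown alone.

Series notes. Compound 1 `O=C(NCc1cc(Cl)ccc1-n1cnnn1)[C@@H]1CC=NN1C(=O)[C@H](O)c1ccccc1` and compound 2 `CC(C)(C)C[C@@H](O)C(=O)N1N=CC[C@H]1C(=O)NCc1cc(Cl)ccc1-n1cnnn1` share one core; compound 3 `O=C(NCc1cc(Cl)ccc1-n1cnnn1)[C@@H]1[C@H]2C[C@H]2CN1C(=O)[C@H](O)c1ccccc1` and compound 4 `CC(C)(C)C[C@@H](O)C(=O)N1C[C@@H]2C[C@@H]2[C@H]1C(=O)NCc1cc(Cl)ccc1-n1cnnn1` share another. The difference between the two cores is not broken down here.

In a functional assay on a cell-free system (plasma, Homo sapiens), with a stated time of 3 min (on this read-out lower numbers stand for stronger inhibition and higher numbers for weaker inhibition), compound 1 gives 840 nM. In this assay compound 2 gives 590 nM. The change from compound 1 to compound 2 is neopentyl in place of phenyl on a saturated chain carbon bound to a carbonyl carbon and an oxygen on a saturated carbon, and it made a 1.4-fold lower number from compound 1 to compound 2 (0.15 log units; within the scatter). In this assay compound 3 gives 960 nM; set against compound 1 and compound 2, all three numbers lie within the scatter of one another, so no order among the three is claimed.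

Compound 4 has not yet been measured. It differs from compound 3 by neopentyl in place of phenyl on a saturated chain carbon bound to a carbonyl carbon and an oxygen on a saturated carbon, which is the same change as that from compound 1 to compound 2, carried onto the other core; the two place descriptions agree word for word. The change has been seen once in a measured pair, and there it stayed within the scatter, so there is no ground to expect anything larger here. For compound 4 the expected step is a 1.4-fold lower number from compound 3 to compound 4 (0.14 log units; within the scatter), taken to match a 1.4-fold lower number from compound 1 to compound 2 (0.15 log units; within the scatter) because compound 3 gives 960 nM and the earlier step lay within the scatter. Compound 4 is therefore estimated at 690 nM in this assay, with a range from 340 nM to 1400 nM.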

Compound 4, half-maximal inhibitory concentration: 910 nM
Compound 4: the middle estimate sits 1.3-fold (0.12 log units) below what was measured, within the range that was stated.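

In this assay the exchange of phenyl for neopentyl on a saturated chain carbon bound to a carbonyl carbon and an oxygen on a saturated carbon gives a 1.1-fold lower number from compound 3 to compound 4 (0.02 log units; within the scatter) and, set beside the earlier step on the core of compound 1, it shows no difference between the two cores: the same change on two cores in this assay, a 1.4-fold lower number (0.15 log units; within the scatter) from compound 1 to compound 2 and a 1.1-fold lower number (0.02 log units; within the scatter) from compound 3 to compound 4, 1.3-fold (0.13 log units) apart, within the scatter of two such steps. Within these two pairs, the change carries from one core to the other as a step that stays inside the scatter both times. This does not show that phenyl or neopentyl is preferred on either core, and two pairs cannot show that the change would behave alike on a further core; any dependence on the core smaller than the scatter would also pass unseen here.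

The compounds shown leave open whether any other group on this chain carbon, such as an amine, a carboxylic acid or a longer chain, would give a step beyond the scatter on either core. They also leave open whether the two cores would differ with such a group in place, and whether the same picture holds on any read-out other than this assay.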